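Shortening the chain from compound 3 to compound 4

This account rests on a few compounds, and the source may have more. Where it says the series, first, only, none or still open, it means among the compounds named here.

Values measured in a functional assay on HeLa cells (Homo sapiens) for cytotoxicity, read by MTT assay, with a stated time of 24 h; a lower number here means a stronger inhibitor, a higher number a weaker inhibitor
compound 1 `CCCCCCCCCCCCCCCCCC(=O)Nc1nnc(S[C@@H]2O[C@H](CO)[C@H](O)[C@H](O)[C@H]2O)s1` gives 11200 nM
compound 2 `CCCCCCCCCC(=O)Nc1nnc(S[C@@H]2O[C@H](CO)[C@H](O)[C@H](O)[C@H]2O)s1` gives 25900 nM
compound 3 `CCCCCCCCCCCCCCCC(=O)Nc1nnc(S[C@@H]2O[C@H](CO)[C@H](O)[C@H](O)[C@H]2O)s1` gives 14200 nM

Compound 3 (14200 nM) lies within the scatter of both other compounds, with a 1.3-fold higher number from compound 1 to compound 3 (0.10 log units; within the scatter) on one side and a 1.8-fold lower number from compound 2 to compound 3 (0.26 log units; within the scatter) on the other. Among the measured compounds shown here, the only step in the set that exceeds the scatter is a 2.3-fold higher number from compound 1 to compound 2 (0.36 log units; beyond the scatter) and it is modest, so the three compounds offer a shallow trend at best.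

The next compound is compound 4 `CCCCCCCCCCCCCC(=O)Nc1nnc(S[C@@H]2O[C@H](CO)[C@H](O)[C@H](O)[C@H]2O)s1` and the change is hydrogen in place of ethyl on a saturated chain carbon, ten or more bonds along the chain from a carbonyl carbon with hydrogen in place of ethyl on a saturated chain carbon, ten or more bonds along the chain from a carbonyl carbon. For the measured compounds named here, the closest precedent is the same exchange made on a longer chain, which gave a 1.3-fold higher number from compound 1 to compound 3 (0.10 log units; within the scatter) and stayed small. The chain of compound 4 is also shorter than that of compound 3 and longer than that of compound 2, so its number is expected to fall near or between those two compounds. The expected change is no step beyond the scatter, estimated as a 1.2-fold higher number from compound 3 to compound 4 (0.09 log units; within the scatter) in this assay and leaning slightly towards a higher number. For compound 4 the estimated value is 17500 nM (expected range 10500 nM to 28000 nM).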

Compound 4, half-maximal inhibitory concentration: 31000 nM
Estimate against measurement, compound 4: 1.8-fold (0.25 log units) below; the whole stated range lies below it.
By their numbers in this assay, from the lowest: compounds 1, 3, 2 and 4 (each within the scatter of the next, the first and the last beyond it).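

In this assay, the loss of ethyl from a saturated chain carbon now gives a step beyond the scatter, a 2.2-fold higher number from compound 3 to compound 4 (0.34 log units; beyond the scatter), while the same exchange on the longer chain stayed within it, a 1.3-fold higher number from compound 1 to compound 3 (0.10 log units; within the scatter), so the size of this change depends on the chain that carries it. The span of the series widens to a 2.8-fold higher number from compound 1 to compound 4 (0.44 log units; beyond the scatter), which sets the longest chain apart from compound 4, yet a 1.2-fold higher number from compound 2 to compound 4 (0.08 log units; within the scatter) shows no separation between those two chains, so compound 2 and compound 4 go against any steady rise in the number as the chain shortens. No measurement at hand bears on the reason for this uneven pattern.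

Open, on these data alone, is whether a longer chain than that of compound 1 would extend the trend in this assay or level off, and whether a chain shorter than that of compound 2 would separate from compound 2 at all. Also open, as far as these compounds go, is how a carboxylic acid or an amine on the saturated chain would compare with the plain chains of compound 1 to compound 4.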